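The source may hold more compounds than are shown below. What is called first, only, known or untested is meant among the compounds shown, and "the series" means these compounds.

Compound 3 `O=S(=O)(NCCCN1CCN(c2ccc(C(F)(F)F)cc2)CC1)c1ccc2ccccc2c1` gives 567 nM in an assay on CHO cells for displacement of a labelled ligand from 5-hydroxytryptamine receptor 7 (Homo sapiens) (on this read-out higher numbers stand for weaker inhibition and lower numbers for stronger inhibition), and stands at the top of the two numbers in hand, yet within the scatter of compound 1 `COc1ccc(S(=O)(=O)NCCCN2CCN(c3ccc(C(F)(F)F)cc3)CC2)cc1`, which gives 384 nM, the step being a 1.5-fold higher number from compound 1 to compound 3 (0.17 log units; within the scatter). Compound 2 `COc1ccc(S(=O)(=O)NCCCN2CCN(c3ccccc3)CC2)cc1` reports only a limit, > 10000 nM. Compound 2 sits at the limit of > 10000 nM in this assay, at which 1 of the 3 values shown sits. Compound 4 `O=S(=O)(NCCCN1CCN(c2ccccc2)CC1)c1ccc2ccccc2c1` differs from compound 3 by hydrogen in place of trifluoromethyl on an aromatic carbon. Among the measured compounds shown here, the one measured step of this kind is an at least 26-fold higher number from compound 1 to compound 2 (1.41 log units; beyond the scatter), a large loss that runs into the limit of this assay. On that basis a step of similar size, a 26-fold higher number from compound 3 to compound 4 (1.42 log units; beyond the scatter), is expected, most likely carrying compound 4 past the limit as well. Compound 4 is therefore estimated at 15000 nM, in the range 4000 nM to 60000 nM.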

Compound 4, half-maximal inhibitory concentration: 681 nM
Beside the measured number, compound 4's estimate is 22-fold (1.34 log units) above it, and the stated range ends above it.
By their numbers in this assay, from the lowest: compounds 1, 3 and 4 (each within the scatter of the next). At a limit, above all of these: compound 2.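

In this assay, hydrogen in place of trifluoromethyl gives a 1.2-fold higher number from compound 3 to compound 4 (0.08 log units; within the scatter), so with naphthalen-2-yl on the sulfonyl sulfur, trifluoromethyl at this position is not required for a number of this size. The outcome of this change depends on the core: the same change on two cores in this assay, an at least 26-fold higher number (1.41 log units; beyond the scatter) from compound 1 to compound 2 and a 1.2-fold higher number (0.08 log units; within the scatter) from compound 3 to compound 4, at least 21-fold (1.33 log units) apart, beyond the scatter of two such steps The value of compound 2, > 10000 nM, is a limit of the assay.

Open, on these data alone, is whether chlorine, methoxy or nitrile at this position follows the same core dependence. Also open, as far as these compounds go, is how a longer chain in the linker would read.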